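Swapping a benzyl for a propyl on a nitro-isoxazole amide

The compounds below may be only part of what the source reports. "The series", "measured", "known", "first", "only" and "open" are said of these compounds alone.

Measured so far:
Compound 1 `COC(=O)c1c([N+](=O)[O-])noc1-c1cc(-c2ccccc2Cl)n(-c2ccccc2)n1`: 79900 nM
Compound 2 `O=C(NCc1ccccc1)c1c([N+](=O)[O-])noc1-c1ccc([N+](=O)[O-])cc1`: "not determined" (no result reported)

In an ADME assay on J774.A1 cells (Mus musculus) for cytotoxicity, read by MTT assay, with a stated time of 48 h (a higher number here means that more compound is tolerated, a lower number that less compound is tolerated), compound 1 gives 79900 nM. In this assay, as far as these compounds go, compound 2 has "not determined" (no result reported), so its position is unknown. Compound 3 `CCCNC(=O)c1c([N+](=O)[O-])noc1-c1ccc([N+](=O)[O-])cc1` differs from compound 2 by a single change: ethyl in place of phenyl on a saturated chain carbon bound to an amide-type nitrogen. Among the compounds with values here, with no measured step between the two, nothing here tells how large that change is or in which direction it acts; it may well stay within the usual scatter. Drawing only on compound 1, the value expected for compound 3 in this assay is 60000 nM, with a likely range of 15000 nM to 200000 nM.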

Compound 3, half-maximal cytotoxic concentration: 76200 nM
Compound 3: middle estimate off by 1.3-fold (0.10 log units), on the low side; the range from low to high includes it.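

No step can be read between compound 2 and compound 3, as compound 2 has no number to compare. The compounds shown leave open what changing benzyl to propyl does to tolerated concentration. No supporting data bear on this result.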